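Sulfonyl aryl replacement: compound 3 to compound 4

The compounds below may be only part of what the source reports. "The series", "measured", "known", "first", "only" and "open" are said of these compounds alone.

Compound 3 `COc1cc(N)c(Cl)cc1C(=O)CCC1CCN(CCNS(=O)(=O)c2cc(Br)ccc2Br)CC1` stands with compound 1 `COc1ccc(S(=O)(=O)NCCN2CCC(CCC(=O)c3cc(Cl)c(N)cc3OC)CC2)cc1Cl` as the two numbered entries in an assay on HEK293 cells for displacement of a labelled ligand from 5-hydroxytryptamine receptor 6 (Homo sapiens), with a stated time of 60 min, tested at 0.01 uM, in the presence of a further agent that is not named here; on this read-out lower numbers stand for a weaker effect and higher numbers for a stronger effect at the one concentration tested: compound 3 gives 16% and compound 1 gives 20%, the step of a number 4 percentage points lower from compound 1 to compound 3 (within the scatter) lying within the scatter. Compound 2 `COc1cc(N)c(Cl)cc1C(=O)CCC1CCN(CCNS(=O)(=O)c2ccc(C)cc2)CC1` is reported in this assay as "not active" (no number reported), without a number. Compound 4 `COc1cc(N)c(Cl)cc1C(=O)CCC1CCN(CCNS(=O)(=O)c2ccc3c(c2)NC(=O)CO3)CC1` differs from compound 3 only at the sulfonyl sulfur: a group of 11 heavy atoms (8 carbon, 1 nitrogen, 2 oxygen; one six-membered non-aromatic ring with 2 hetero atoms, one six-membered aromatic ring of carbon only) in place of a group of 8 heavy atoms (6 carbon, 2 bromine; one six-membered aromatic ring of carbon only), on a sulfonyl sulfur. Going by the values given here, the one measured step at this position, a number 4 percentage points lower from compound 1 to compound 3 (within the scatter), stayed within the scatter, and compound 2, also changed there, gave no number, so no step beyond the scatter in this assay is expected in either direction. Compound 4 is therefore estimated at 16%, between 4% and 30%, an expected step of no change at the digits printed from compound 3 to compound 4 (within the scatter).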

Compound 4, a percentage reported as inhibition, at one concentration (the size of the read-out at that concentration, not a potency): "not active" (no number reported)
The entry for compound 4 holds no number, and the estimate cannot be compared.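

Going by these compounds alone, compound 4 is reported as "not active" without a number in this assay, so no step from compound 3 to compound 4 can be read. No measurement shown bears on this result. The compounds shown leave open whether any change on the sulfonyl sulfur moves this read-out beyond the scatter.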